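The compounds below may be only part of what the source reports. "The series", "measured", "known", "first", "only" and "open" are said of these compounds alone.

Compound 1 `COc1ccccc1OCc1cc(C)nc(-c2ccccn2)n1`: 2000 nM
Compound 2 `Cc1cc(COc2cccc(C#N)c2)nc(-c2ccccn2)n1`: 2510 nM

Of the compounds shown here, two have so far been measured in a functional assay on cells for antagonist activity at Free fatty acid receptor 1 (Homo sapiens), read by TR-FRET and inositol phosphate accumulation, with a stated time of 2 h; a higher number here means a weaker inhibitor, a lower number a stronger inhibitor. Compound 1 gives 2000 nM, and compound 2 gives 2510 nM. The gap between these two numbers lies within the usual scatter of repeated measurements, so on these data the two compounds cannot be told apart, and compound 1 is not singled out by its number; it simply serves as the starting point for the next step.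

Compound 3 `CC(=O)Nc1ccccc1OCc1cc(C)nc(-c2ccccn2)n1` has not yet been measured. It differs from compound 1 in one place: acetamido in place of methoxy on an aromatic carbon. Going by the values given here, no pair of measured compounds shows what such a swap does in this assay, so the size and direction of the step have to be estimated without a precedent. The expected step is a 1.3-fold higher number from compound 1 to compound 3 (0.10 log units; within the scatter), which means no change beyond the scatter, with a slight lean toward a higher number. Compound 3 is therefore estimated at 2500 nM, with a range from 800 nM to 8000 nM.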

Compound 3, half-maximal inhibitory concentration: > 39800 nM
Compound 3: only a limit was reported; the forecaster's own chance of this, stated with the estimate: 15%; middle value at least 15-fold (1.20 log units) from the limit.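

Until now, nothing showed whether the group on this aromatic carbon, ortho to a large group, mattered in this assay, but putting acetamido in place of methoxy gives an at least 19-fold higher number from compound 1 to compound 3 (1.29 log units; beyond the scatter), a large weakening of inhibition from a single change. On these data alone, compound 3 has only a limit and not an exact number, so this step is a minimum and its true size remains unknown: the limit of > 39800 nM in this assay, at which 1 of the 3 values shown sits. The swap brings in more heavy atoms and a hydrogen-bond donor together, and this one pair cannot show which of these differences counts, so it establishes only that this position does not accept every group in this assay.

The compounds shown leave open whether a small group such as an amine or a hydroxyl on this carbon, or a longer chain such as ethoxy, would keep inhibition near that of compound 1. They also leave open whether acetamido would weaken inhibition as much on another carbon of the same ring.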